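This account rests on a few compounds, and the source may have more. Where it says the series, first, only, none or still open, it means among the compounds named here.

Of the compounds shown here, three have been measured in a functional assay on KYSE-410 cells (Homo sapiens) for antiproliferative activity, read by MTT assay, with a stated time of 72 h (on this read-out higher numbers stand for weaker inhibition and lower numbers for stronger inhibition), and a fourth awaits its number. Compound 1 `COc1ccc(OC)c(NC(=O)c2cc(=O)[nH]c3cc(Br)ccc23)c1` gives only a limit in this assay, > 20000 nM. Compound 2 `O=C(Nc1cccc(C(F)(F)F)c1)c1cc(=O)[nH]c2cc(Br)ccc12` likewise reaches only a limit in this assay, > 20000 nM. Going by the values given here, compound 3 `O=C(Nc1cccc(F)c1)c1cc(=O)[nH]c2cc(-c3ccc(F)cc3)ccc12` is the one member with a measured value: in this assay compound 3 gives 10300 nM, and so it stands as the only real number among the three. Compound 1 and compound 2 instead sit at the limit of > 20000 nM in this assay, at which 2 of the 3 values shown sit.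

Compound 4 `Cc1cc(-c2ccc3c(C(=O)Nc4cccc(F)c4)cc(=O)[nH]c3c2)c(C)cc1F` has not yet been measured. It is built from compound 3 by a single change on the shared core: 4-fluoro-2,5-dimethylphenyl in place of 4-fluorophenyl on an aromatic carbon. Among the compounds with values here, the two methyl groups on the entering ring are the whole of the difference, and no measured pair in this set shows what such a change does.

With nothing to steer the expectation, the step from compound 3 to compound 4 is expected to stay within the ordinary scatter of this assay, a 1.1-fold lower number from compound 3 to compound 4 (0.06 log units; within the scatter). Compound 4 is therefore expected to give 9000 nM in this assay, with a plausible range from 3000 nM to 25000 nM, and with some chance that only a limit is reported.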

Compound 4, half-maximal inhibitory concentration: > 20000 nM
Compound 4 gave a limit, no number; the forecaster's own chance of this, stated with the estimate: 30%; middle value at least 2.2-fold (0.34 log units) away from the limit.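

In this assay, putting 4-fluoro-2,5-dimethylphenyl in place of 4-fluorophenyl on this aromatic carbon gives an at least 1.9-fold higher number from compound 3 to compound 4 (0.28 log units; that floor lies within the scatter). Going by these compounds alone, this is the first step that can be read at this position, and it shows that adding the two methyl groups to the ring brings no gain in inhibition, although compound 4 gives only a limit, so the step is a floor and the true size of the change remains unknown; that floor alone does not establish a real loss. Compound 3 therefore remains the only compound with a real number, while compound 4 joins the others that stop at the limit: the limit of > 20000 nM in this assay, at which 3 of the 4 values shown sit.

The compounds shown leave open whether a single methyl group on the 4-fluorophenyl ring would be tolerated, and which of the two methyl groups matters more for the result. They also leave open whether a different group on that ring, such as an amine or a carboxylic acid, would bring the number lower than that of compound 3.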